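The compounds below may be only part of what the source reports. "The series", "measured", "known", "first", "only" and "open" are said of these compounds alone.

Of the compounds shown here, two sharing one core have been measured so far in a functional assay on the whole organism (strain Wistar albino) for inhibition, with Rattus norvegicus as the target, read by paw edema, with stated times of 1 h and 2 h, at a dose of 0.32 mmol/kg by the intraperitoneal route; on this read-out higher numbers stand for more inhibition at the one dose given (going by the name of the read-out) and lower numbers for less inhibition. Compound 1 `COc1ccc(-c2nn(-c3ccc(Cl)cc3)cc2/C=N\c2ccccc2)cc1` gives 57.2% in this assay. Going by the values given here, compound 2 `COc1ccc(/N=C\c2cn(-c3ccc(Cl)cc3)nc2-c2ccc(OC)cc2)cc1` gives 69.2% in this assay, the higher of the two numbers, and the single step between them, a number 12 percentage points higher from compound 1 to compound 2 (beyond the scatter), came with methoxy in place of hydrogen on an aromatic carbon. Compound 3 `COc1ccc(-c2nn(-c3ccc(Cl)cc3)cc2/C=N\c2ccc(Cl)cc2)cc1` is the compound that is to be measured next; it differs from compound 2 by chloro in place of methoxy on an aromatic carbon, so that 4-methoxyphenyl becomes 4-chlorophenyl. Among the compounds with values here, no measured step exchanges chloro for methoxy. Within the data shown here, the only step bearing on this position, a number 12 percentage points higher from compound 1 to compound 2 (beyond the scatter), shows that the ring without methoxy gave the lower number. Since chloro is neither hydrogen nor methoxy, a small downward step, possibly within the scatter, is expected for compound 3, a number 6.2 percentage points lower from compound 2 to compound 3 (within the scatter). Compound 3 is therefore estimated at 63% in this assay, with a range from 52% to 74%.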

Compound 3, a percentage reported as inhibition, in the whole organism at one dose (the size of the read-out at that dose, not a potency): 69.6%
For compound 3 the middle estimate is 6.6 percentage points below the measured one; the range from low to high includes it.
By their numbers in this assay, from the lowest: compound 1; then compounds 2 and 3 (each within the scatter of the next).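

In this assay, chloro in place of methoxy gave a number 0.4 percentage points higher from compound 2 to compound 3 (within the scatter), so at this place on the ring the two groups cannot be told apart. Chloro in place of hydrogen gave a number 12.4 percentage points higher from compound 1 to compound 3 (beyond the scatter), so the gain over the unsubstituted ring seen earlier with methoxy is not unique to methoxy, since two different groups now share it. The data offer no measurement that explains why these two groups read alike.

As far as these compounds go, whether an amine, a carboxylic acid or a longer chain such as butoxy at this place would hold the number or lose it remains open. From the compounds shown here alone, the rest of the shared core is the same in all three compounds, so what a change elsewhere would do is also open.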